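Cytotoxicity of a thiadiazole amide series in MT4 cells

The source may hold more compounds than are shown below. What is called first, only, known or untested is meant among the compounds shown, and "the series" means these compounds.

The series shares one core, a dibromophenyl-bearing thiadiazole joined through a sulfur-linked acetamide to an aryl or heteroaryl amine. Compound 1 `O=C(CSc1snnc1-c1ccc(Br)cc1Br)Nc1ccccn1` carries a pyridin-2-yl on the amide nitrogen; in an ADME assay on MT4 cells (Homo sapiens) for cytotoxicity, read by MTT assay, with a stated time of 5 days (on this read-out lower numbers stand for higher toxicity in this test and higher numbers for lower toxicity in this test), compound 1 gives 42400 nM. Compound 2 `Cc1cccc(NC(=O)CSc2snnc2-c2ccc(Br)cc2Br)c1C` carries a 2,3-dimethylphenyl instead, and in this assay compound 2 gives 241000 nM. Among the compounds with values here, the one measured step, a 5.7-fold higher number from compound 1 to compound 2 (0.75 log units; beyond the scatter), is the only comparison so far, and it places compound 2 at the higher of the two numbers, the less toxic end of what has been measured.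

Compound 3 `Cc1ccc(NC(=O)CSc2snnc2-c2ccc(Br)cc2Br)c(Br)c1` differs from compound 2 by the change (2-bromo-4-methylphenyl in place of 2,3-dimethylphenyl on an amide-type nitrogen). Within the data shown here, no measured step swaps one substituted phenyl for another; the only step known exchanges a pyridinyl for a phenyl and is therefore at best a weak guide. With both compounds bearing a substituted phenyl of the same size on the amide nitrogen, the step of a 1.3-fold lower number from compound 2 to compound 3 (0.13 log units; within the scatter) is expected to stay within the scatter. Compound 3 is accordingly estimated at 180000 nM in this assay, with a range from 70000 nM to 400000 nM.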

Compound 3, half-maximal cytotoxic concentration: > 216000 nM
Compound 3 ended at the assay's limit; the forecaster's own chance of this, stated with the estimate: 20%; at least 1.2-fold (0.07 log units) between middle value and limit.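

In this assay compound 3 reads > 216000 nM, which is a limit of the assay and not a number: the limit of > 216000 nM in this assay, at which 1 of the 3 values shown sits. The step between compound 2 and compound 3 therefore cannot be read, and the 2,3-dimethylphenyl and the 2-bromo-4-methylphenyl stay unordered on this amide-type nitrogen. What the result does add is a second substituted phenyl that stands clear of the pyridin-2-yl, with an at least 5.0-fold higher number from compound 1 to compound 3 (0.70 log units; beyond the scatter), in the same direction as a 5.7-fold higher number from compound 1 to compound 2 (0.75 log units; beyond the scatter), so among these three compounds the pyridin-2-yl of compound 1 goes with the lowest number and no compound goes against this.

The compounds shown leave open what a plain phenyl, or a phenyl carrying an amine or a carboxylic acid, would give on this nitrogen in this assay. From the compounds shown here alone, it is also open whether a pyridin-2-yl carrying a methyl group would stay with compound 1 or move toward compound 2 and compound 3, and whether the higher numbers belong to the phenyl ring itself or to what it carries.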